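This account rests on a few compounds, and the source may have more. Where it says the series, first, only, none or still open, it means among the compounds named here.

In a functional assay on MCF7 cells (Homo sapiens) for antiproliferative activity, read by MTT assay, with a stated time of 24 h (on this read-out higher numbers stand for weaker inhibition and lower numbers for stronger inhibition), compound 1 `CCn1c(C(=O)N[C@@H](CO)CCO)ccc1C(CC)(CC)c1ccc(OCS(=O)(=O)c2ccccc2)c(C)c1` gives 27400 nM. Compound 2 `CCn1c(C(=O)N[C@H](C(=O)O)C(C)C)ccc1C(CC)(CC)c1ccc(OCS(=O)(=O)c2ccccc2)c(C)c1` gives 24500 nM, the lower of the two numbers, although the two values lie within the scatter of each other. Compound 3 `CCn1c(C(=O)N[C@@H](C(=O)O)C(C)C)ccc1C(CC)(CC)c1ccc(OCS(=O)(=O)c2ccccc2)c(C)c1` has not yet been measured. Its relation to compound 2 is the two compounds have the same atoms and bonds and differ only in configuration as drawn: 1 of 1 stereo elements differ; a stereocentre at a saturated chain carbon is drawn S in compound 2 and R in compound 3: the two compounds have the same atoms and bonds, and the stereocentre at a saturated chain carbon is drawn S in compound 2 and R in compound 3. Among the measured compounds shown here, the only measured step is a 1.1-fold lower number from compound 1 to compound 2 (0.05 log units; within the scatter). For the measured compounds named here, it replaces the group on an amide-type nitrogen, so it does not test a change of configuration, and no measured pair does. With no evidence for a shift in either direction, the expected step is a 1.0-fold higher number from compound 2 to compound 3 (0.01 log units; within the scatter), with none beyond the scatter anticipated in this assay. For compound 3 the estimated value is 25000 nM, within an expected range of 12000 nM to 50000 nM.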

Compound 3, half-maximal inhibitory concentration: 44700 nM
Beside the measured number, compound 3's estimate is 1.8-fold (0.25 log units) below it, and the stated range covers the measured number.
By their numbers in this assay, from the lowest: compounds 2, 1 and 3 (each within the scatter of the next).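

In this assay, changing the stereocentre at a saturated chain carbon from S to R gives a 1.8-fold higher number from compound 2 to compound 3 (0.26 log units; within the scatter), so this first measured test of configuration at this position shows no shift beyond the scatter. The other new step, a 1.6-fold higher number from compound 1 to compound 3 (0.21 log units; within the scatter), with 1-carboxy-2-methylpropyl in place of 3-hydroxy-1-(hydroxymethyl)propyl on an amide-type nitrogen, also stays within the scatter, so this replacement shows no readable effect with either drawn configuration. The comparison between the S and R forms bears on configuration alone: the fact that compounds 2 and 3 differ only in the configuration as drawn

The compounds shown leave open whether a methyl ester or a primary amide in place of the carboxylic acid would give a number beyond the scatter. They also leave open whether configuration would matter with an amine or a longer chain on the amide-type nitrogen.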